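The source may hold more compounds than are shown below. What is called first, only, known or untested is meant among the compounds shown, and "the series" means these compounds.

Three compounds with a shared core, each carrying a long saturated chain, have been tested in a functional assay on cells (Lymphocyte, Homo sapiens) for inhibition, read by flow cytometry, using a membrane potential dye, with a stated time of 16 h, tested at 100 nM; a higher number here means a stronger effect of the compound at the concentration tested, a lower number a weaker effect. Compound 1, with the structure `CCCCCCCCCCc1c(C)c(N(C)C)nc(C)c1O`, gives 60% in this assay. Compound 2, with the structure `CCCCCCCCCCc1nc(N(C)C)c(C)c(C)c1O`, is built from the same atoms joined differently; how the two cores differ is not broken down here. In this assay compound 2 gives 65%, which lies within the scatter of the number for compound 1, so the two cannot be told apart. Compound 3, with the structure `CCCCCCCCCCCCCCCCCCCc1c(C)c(N(C)C)nc(C)c1O`, carries a much longer chain than compound 1 does; in this assay compound 3 gives 23%. The change from compound 1 to compound 3 is nonyl in place of hydrogen on a saturated chain carbon, ten or more bonds along the chain from an aromatic carbon, and it made a step of a number 37 percentage points lower from compound 1 to compound 3 (beyond the scatter), well beyond the scatter.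

Compound 4, with the structure `CCCCCCCCCCCCCCCCCCCc1nc(N(C)C)c(C)c(C)c1O`, has not yet been measured. It stands to compound 2 as compound 3 stands to compound 1: the change is nonyl in place of hydrogen on a saturated chain carbon, ten or more bonds along the chain from an aromatic carbon, and the place of the change is the same in both pairs. Among the measured compounds shown here, because the only measured example of this change, a number 37 percentage points lower from compound 1 to compound 3 (beyond the scatter), was a large drop, a step of similar size is expected from compound 2 to compound 4, namely a number 37 percentage points lower from compound 2 to compound 4 (beyond the scatter). On that basis compound 4 is expected to give about 28% in this assay, with a plausible range from 14% to 44%. This rests on one measured pair only, and compound 2 and compound 4 may not follow it.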

Compound 4, a percentage reported as activity, at one concentration (the size of the read-out at that concentration, not a potency): 24%
The estimate for compound 4 lay 4 percentage points above the measured number; the measured number falls inside the stated range.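

Lengthening the chain on the second core gave, in this assay, a number 41 percentage points lower from compound 2 to compound 4 (beyond the scatter), so the large drop seen on the first core appeared again on the second. Placed side by side, the two steps cannot be told apart, which means that in this small set the change carried over from one core to the other with much the same size: the same change on two cores in this assay, a number 37 percentage points lower (beyond the scatter) from compound 1 to compound 3 and a number 41 percentage points lower (beyond the scatter) from compound 2 to compound 4, 4 percentage points apart, within the scatter of two such steps This is still only two pairs, on two cores built from the same atoms, and each read-out comes from a single concentration, so it shows neither that the change would behave the same way on a more different core nor why the longer chain lowers the number.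

The compounds shown leave open how the number moves with chain length, since only a short step along the series would show whether it falls gradually or suddenly somewhere between the two lengths tested, and a shorter chain would show whether the trend extends in the other direction. They also leave open whether a chain of the same length carrying an amine or a carboxylic acid would give a similar drop on either core.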